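Series notes: methoxycarbonyl to carboxy, compound 1 to compound 4

The compounds below may be only part of what the source reports. "The series", "measured", "known", "first", "only" and "open" are said of these compounds alone.

Measured so far in an assay on isolated protein for inhibition of alkaline phosphatase, tissue-nonspecific isozyme (Homo sapiens); on this read-out lower numbers stand for stronger inhibition and higher numbers for weaker inhibition:
Compound 1, `COC(=O)c1cncc(NS(=O)(=O)c2cc(Cl)ccc2OC)c1`, is reported only as a limit of the assay, > 20000 nM.
Compound 2, `COc1ccc(Br)cc1S(=O)(=O)Nc1cccnc1`, gives 543 nM.
Compound 3, `COc1ccc(Cl)cc1S(=O)(=O)Nc1cnc2ccccc2c1`, gives 4510 nM.

Compound 1 stands apart from the other two numbers shown: its value is not a number but (the limit of > 20000 nM in this assay, at which 1 of the 3 values shown sits), so no step from compound 1 to compound 2 or to compound 3 can be sized. Going by the values given here, compound 2 and compound 3 each show a number where compound 1 shows none; no step between compound 2 and compound 3 is counted here, so only their two values are stated.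

Compound 4, `COc1ccc(Cl)cc1S(=O)(=O)Nc1cncc(C(=O)O)c1`, awaits measurement in this assay. It differs from compound 1 in one place: hydrogen in place of methyl on an oxygen next to a carbonyl group. Read one bond further out, this is methoxycarbonyl to carboxy.

Among the compounds with values here, no measured pair isolates this change, so the expectation rests on compound 1 alone, and compound 1 offers only a limit. The step is expected to be an at least 1.3-fold lower number from compound 1 to compound 4 (0.12 log units; that floor lies within the scatter), a direction not relied on beyond the scatter. Compound 4 is estimated at 15000 nM, within 3000 nM to 60000 nM, with a fair chance that the assay again reports only a limit.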

Compound 4, half-maximal inhibitory concentration: > 20000 nM
Compound 4: only a limit was reported (the forecaster's own chance of this, stated with the estimate: 45%); at least 1.3-fold (0.12 log units) between middle value and limit.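

Compound 4, like compound 1, is reported in this assay only as a limit of the assay, so no step between the two can be read: the limit of > 20000 nM in this assay, at which 2 of the 4 values shown sit.

The compounds shown leave open whether methoxycarbonyl to carboxy changes inhibition at all in this assay on a member of the series that gives a number.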